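From Furanoyl Ketone to Isopropyl Amide on a Shared Core

This account rests on a few compounds, and the source may have more. Where it says the series, first, only, none or still open, it means among the compounds named here.

Of the compounds shown here, two carry numbers so far. Compound 1 (`COC(=O)N1CC2CNCC2C1`) gives 23 nM in an assay on SHEP1 cells for displacement of a labelled ligand from Neuronal acetylcholine receptor; alpha4/beta2 (Homo sapiens), read by scintillation counting, with a stated time of 2 h; a higher number here means a weaker inhibitor, a lower number a stronger inhibitor. Compound 2 (`O=C(c1ccco1)[C@H]1C[C@@H]2CNC[C@@H](C2)C1`) gives 110 nM in this assay, the higher of the two numbers, and its gap to compound 1 lies beyond the usual scatter of repeated measurements.

Compound 3 (`CC(C)NC(=O)[C@H]1C[C@@H]2CNC[C@@H](C2)C1`) is the next candidate. It differs from compound 2 by isopropylamino in place of furan-2-yl on a carbonyl carbon. The carbonyl and the saturated bicyclic core are kept; only the group on the carbonyl carbon changes, from an aromatic ring to a short chain carrying one hydrogen-bond donor.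

Within the data shown here, no measured pair shows this particular change, so there is nothing to anchor its direction. Among the measured compounds shown here, compound 1, with its carbamate on the core, shows that a non-aromatic carbonyl substituent can give a low number, but its core and attachment differ from those of compound 2, so it offers no direct step. The expected step is a 1.4-fold higher number from compound 2 to compound 3 (0.13 log units; within the scatter), in either direction, and it is unlikely to exceed the scatter by much. Compound 3 is estimated at 150 nM, with a range from 30 nM to 700 nM.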

Compound 3, inhibition constant: 23 nM
Compound 3: middle estimate off by 6.5-fold (0.81 log units), on the high side, outside the stated range (below it).
By their numbers in this assay, from the lowest: compounds 1 and 3 (each within the scatter of the next); then compound 2.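

Among these compounds, on the core shared by compound 2 and compound 3, isopropylamino in place of furan-2-yl on a carbonyl carbon gives a 4.8-fold lower number from compound 2 to compound 3 (0.68 log units; beyond the scatter) in this assay and provides the first measured step at this position. It shows that a five-membered aromatic ring on this carbonyl carbon is not required for a low number within this pair, since compound 3, which has no ring in the entering group, gives 23 nM in this assay. The change removes the furan ring and its oxygen and brings in a nitrogen with 1 hydrogen-bond donor, and nothing available here bears on which of these differences accounts for the step.

The compounds shown leave open whether the amide hydrogen matters, a question that a dimethylamino group on the same carbonyl carbon could address. They also leave open how far the trend extends along this single step, since neither a longer chain such as n-butylamino nor a phenyl ring in place of furan-2-yl appears among them.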